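The source may report more compounds than this note shows. Statements on the series, on what has been measured and on what is new or still open speak of the compounds shown alone.

Working notes on the series. In a functional assay on HT-29 cells (Homo sapiens) for inhibition, read by MTT assay (on this read-out lower numbers stand for stronger inhibition and higher numbers for weaker inhibition), compound 1 (`COc1ccc2c(c1)CC[C@H](O)/C2=C/c1cc(OC)c(OC)c(OC)c1`) gives 1 nM, compound 2 (`COc1ccc(/C=C2\c3cc(OC)c(OC)c(OC)c3CC[C@@H]2O)cc1[N+](=O)[O-]`) gives 1590 nM and compound 3 (`COc1ccc(/C=C2\c3cc(OC)c(OC)c(OC)c3CC[C@H]2O)cc1F`) gives 220 nM. Compound 3 therefore sits in the middle of the three, with a higher number than compound 1 and a lower number than compound 2, and both gaps lie beyond the usual scatter.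

Next is compound 4 (`COc1ccc(/C=C2\c3cc(OC)c(OC)c(OC)c3CC[C@H]2O)cc1C`), still unmeasured in this assay. The change is methyl in place of fluoro on an aromatic carbon, taking 3-fluoro-4-methoxyphenyl to 4-methoxy-3-methylphenyl. Going by the values given here, no measured pair differs in one place only, so the data offer no direct guide to this swap. The expectation therefore rests on compound 3 at 220 nM, with a wide margin. The expected step of a 1.4-fold higher number from compound 3 to compound 4 (0.13 log units; within the scatter) is small, leaning towards a slightly higher number and probably not beyond the scatter. For compound 4 the estimated value is 300 nM, with an expected range of 70 nM to 1300 nM.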

Compound 4, half-maximal inhibitory concentration: 3970 nM
For compound 4 the middle estimate is 13-fold (1.12 log units) below the measured one; measured number outside the range, above it.
By their numbers in this assay, from the lowest: compound 1; then compound 3; then compound 2; then compound 4.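

In this assay, going by these compounds alone, methyl in place of fluoro on an aromatic carbon, ortho to a methoxy group, gives the first one-place step: an 18-fold higher number from compound 3 to compound 4 (1.26 log units; beyond the scatter), a large change. This position therefore tells apart two groups that match in heavy-atom count, with no hydrogen-bond donors or acceptors and no net charge on either side, so those counts alone do not set the read-out here. No accompanying measurement accounts for the size of this step.

As far as these compounds go, whether a chloro group or a hydroxyl group at this position would stay close to compound 3 or fall close to compound 4 remains open. Also open, from the compounds shown here alone, is whether the same swap would give a step of similar size on the core of compound 1.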